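The compounds below may be only part of what the source reports. "The series", "measured", "known", "first", "only" and "open" are said of these compounds alone.

Measured so far in a functional assay on HCT-15 cells (Homo sapiens) for antiproliferative activity, read by sulforhodamine B assay, with a stated time of 48 h, tested at 50 uM; a lower number here means less inhibition, a higher number more inhibition at the concentration tested (going by the name of the read-out):
compound 1 `COc1ccc(C(=O)Oc2cc3c(cc2C)[C@@H](C(C)C)CC=C3C)cc1`, giving 30.8%
compound 2 `CC1=CC[C@H](C(C)C)c2cc(C)c(OC(=O)c3cccc(C)c3)cc21`, giving 5.3%

Compound 1 stands highest of these two numbers; its nearest neighbour is compound 2, reached by a number 25.5 percentage points lower from compound 1 to compound 2 (beyond the scatter). Compound 3 `CC1=CC[C@H](C(C)C)c2cc(C)c(OC(=O)c3ccc(Cl)cc3)cc21` differs from compound 1 by chloro in place of methoxy on an aromatic carbon. Among the compounds with values here, the single measured step, a number 25.5 percentage points lower from compound 1 to compound 2 (beyond the scatter), alters the same ester aryl group, to a 3-methylphenyl, so it bears on this change only loosely. Some loss in this assay is therefore expected, but a smaller one than that step. Compound 3 is expected to give 18%, range 3% to 38%, an estimated step of a number 12.8 percentage points lower from compound 1 to compound 3 (beyond the scatter).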

Compound 3, a percentage reported as inhibition, at one concentration (the size of the read-out at that concentration, not a potency): 47.4%
Compound 3: middle estimate off by 29.4 percentage points, on the low side, and the stated range ends below it.
By their numbers in this assay, from the lowest: compound 2; then compound 1; then compound 3.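

Replacing methoxy with chloro on the ester aryl ring gives a number 16.6 percentage points higher from compound 1 to compound 3 (beyond the scatter) in this assay and so shows that the ester aryl group can gain inhibition as well as lose it. The change from 3-methylphenyl to 4-chlorophenyl gives a number 42.1 percentage points higher from compound 2 to compound 3 (beyond the scatter) and so makes the choice of ester aryl group a large determinant of the read-out in these three compounds. Nothing available explains either rise.

As far as these compounds go, whether the gain is specific to chloro remains open. A bromo, an amine or a carboxylic acid at the same place would test this, as would 3-chlorophenyl for the role of ring position.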